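Trimming One Ester Side Chain in a Receptor Blocker

The source may hold more compounds than are shown below. What is called first, only, known or untested is meant among the compounds shown, and "the series" means these compounds.

Compound 1 `CCCOC(=O)c1[nH]cc(C(=O)OC(C)C(C)(C)C)c1C`: 4 nM
Compound 2 `Cc1c(C(=O)OC(C)C(C)(C)C)c[nH]c1C(=O)OC(C)CN(C)C`: 390 nM
Compound 3 `Cc1c(C(=O)OC(C)(C)C)c[nH]c1C(=O)OCC1CC1`: 48 nM

In an assay on CHO cells for inhibition of metabotropic glutamate receptor 1 (Rattus norvegicus) (a lower number here means a stronger inhibitor, a higher number a weaker inhibitor), compound 1 gives the lowest number of the three; compound 3 lies clearly above it, and compound 2 lies furthest above. Among the compounds with values here, the only step between two compounds that differ in one place is a 98-fold higher number from compound 1 to compound 2 (1.99 log units; beyond the scatter), which concerns the other ester and so says little about the change considered here. Compound 4 `CCCOC(=O)c1[nH]cc(C(=O)OC(C)(C)C)c1C` differs from compound 1 by tert-butyl in place of 1,2,2-trimethylpropyl on an oxygen next to a carbonyl group. Compound 3 also carries tert-butyl on this oxygen, but it differs from compound 1 at the other ester too, so its gap cannot be assigned to one change. A modest weakening is therefore expected, a 3.0-fold higher number from compound 1 to compound 4 (0.48 log units; beyond the scatter). Compound 4 is estimated at 12 nM, likely between 3 nM and 50 nM.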

Compound 4, half-maximal inhibitory concentration: 75 nM
Estimate against measurement, compound 4: 6.3-fold (0.80 log units) below; the whole stated range lies below it.
By their numbers in this assay, from the lowest: compound 1; then compounds 3 and 4 (each within the scatter of the next); then compound 2.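

Within the data shown here, replacing 1,2,2-trimethylpropyl with tert-butyl on this oxygen gives the first clean reading of this ester: in this assay, the change produces a 19-fold higher number from compound 1 to compound 4 (1.27 log units; beyond the scatter). At the other ester, the swap read from tert-butyl compounds gives a 1.6-fold higher number from compound 3 to compound 4 (0.19 log units; within the scatter), so with tert-butyl in place, that change shows no clear effect. Nothing available here explains the large step at the first ester. From the compounds shown here alone, how a cyclohexyl group or a longer chain on this oxygen would compare remains open, as does whether 1,2,2-trimethylpropyl is the best group there.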